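The source may report more compounds than this note shows. Statements on the series, on what has been measured and on what is new or still open speak of the compounds shown alone.

Measured in a functional assay on HL-60 cells (Homo sapiens) for cytotoxicity, read by MTT assay, with a stated time of 48 h; on this read-out lower numbers stand for stronger inhibition and higher numbers for weaker inhibition:
- compound 1 `CCNc1n[n+]([O-])c2ccccc2[n+]1[O-]`: 9000 nM
- compound 2 `CCCCCCCCNc1n[n+]([O-])c2ccccc2[n+]1[O-]`: 7200 nM
- compound 3 `CCN(CC)c1n[n+]([O-])c2ccccc2[n+]1[O-]`: > 49000 nM (a limit)

Compound 1 and compound 2 lie within the scatter of each other, with a 1.3-fold lower number from compound 1 to compound 2 (0.10 log units; within the scatter). Compound 3 gives only a limit, > 49000 nM.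

Next is compound 4 `[O-][n+]1nc(Nc2ccccc2)[n+]([O-])c2ccccc21`, with phenyl in place of ethyl on a nitrogen on an aromatic ring.

Going by the values given here, two measured steps bear on this change. Hexyl added to the chain gave a 1.3-fold lower number from compound 1 to compound 2 (0.10 log units; within the scatter), so a larger group on that nitrogen made no difference beyond the scatter in this one case. Ethyl in place of hydrogen on the nitrogen gave an at least 5.4-fold higher number from compound 1 to compound 3 (0.73 log units; beyond the scatter). Compound 4 keeps that hydrogen, so this second step is a weaker guide. No phenyl group has been measured in the series, which leaves the expectation loose.

Going by a 1.3-fold lower number from compound 1 to compound 2 (0.10 log units; within the scatter), no step beyond the scatter is expected in this assay. The expected step is a 1.1-fold lower number from compound 1 to compound 4 (0.05 log units; within the scatter). Compound 4 is estimated at 8000 nM, with an expected range of 3000 nM to 25000 nM.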

Compound 4, half-maximal inhibitory concentration: 2900 nM
The estimate for compound 4 lay 2.8-fold (0.44 log units) above the measured number, and the stated range ends above it.
By their numbers in this assay, from the lowest: compound 4; then compounds 2 and 1 (each within the scatter of the next). At a limit, above all of these: compound 3.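

In this assay, phenyl in place of ethyl gives a 3.1-fold lower number from compound 1 to compound 4 (0.49 log units; beyond the scatter), the first step toward a lower number beyond the scatter in the compounds shown. On this nitrogen, which keeps its hydrogen in both compounds, a six-membered aromatic ring therefore does what the longer chain of compound 2 did not do, as that chain's step stayed within the scatter. No measurement shown accounts for the step from ethyl to phenyl.

On these data alone, whether the aromatic ring itself matters stays open, and a cyclohexyl or benzyl group on the same nitrogen would address this, as would a methoxy or chloro group on the phenyl ring. Also open, as far as these compounds go, is whether a phenyl group would hold its effect on a nitrogen without hydrogen, the kind of nitrogen found in compound 3.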